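The source may report more compounds than this note shows. Statements on the series, on what has been measured and on what is new or still open speak of the compounds shown alone.

Working notes on the series. Within the data shown here, compound 1 `CC(C(=O)NCc1ccc(C(F)(F)F)cc1)N1C(=O)CCC1=O` is the only member with a number in a functional assay on the whole organism (strain Albino Swiss CD1) with Mus musculus as the target, in the maximal electroshock model; a lower number here means that less compound is needed, a higher number that more compound is needed for the effect: compound 1 gives 80.1 mg/kg. Compound 2 `CCC(C(=O)NCc1ccc(F)cc1)N1C(=O)CCC1=O` has no result in this assay; for compound 2 the entry reads "not determined" (no result reported), so compound 2 stands nowhere on the numbers and offers no anchor of its own.

Compound 3 `CCC(C(=O)NCc1ccc(C(F)(F)F)cc1)N1C(=O)CCC1=O` is not yet measured. Compound 3 differs from compound 2 by trifluoromethyl in place of fluoro on an aromatic carbon. Among the measured compounds shown here, no measured pair carries this exchange, and compound 2 itself has no value, so the size of the step in this assay cannot be read from data; the expectation is that the step from compound 2 to compound 3 changes the dose for half-maximal effect by no more than the usual scatter, in either direction, with no basis to prefer one direction.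

For the measured compounds named here, the only number available, that of compound 1 at 80.1 mg/kg, is the working reference for the series. For compound 3 the expected value in this assay is estimated at 75 mg/kg, with a range of 30 mg/kg to 180 mg/kg.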

Compound 3, dose for half-maximal effect: 69.4 mg/kg
The estimate for compound 3 lay 1.1-fold (0.03 log units) above the measured number; the range from low to high includes it.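

In this assay the series now has its first readable step, a 1.2-fold lower number from compound 1 to compound 3 (0.06 log units; within the scatter), for methyl in place of hydrogen on a saturated chain carbon, two bonds along the chain from an amide-type nitrogen in a ring and a carbonyl carbon. With trifluoromethyl held on the aromatic carbon in both members of this pair, the added methyl at this chain carbon stays within the usual scatter, whereas the exchange of fluoro for trifluoromethyl cannot be read as a step, as compound 2 has no number in this assay to set against compound 3. No measurement is at hand that bears on this result.

As far as these compounds go, this single pair speaks only for methyl in place of hydrogen with trifluoromethyl on the aromatic carbon, so whether a longer chain such as propyl, or a chain ending in an amine, would also stay within the scatter at this carbon remains open. Equally open, from the compounds shown here alone, is the effect of any other group, such as chloro or nitrile, in place of trifluoromethyl on the aromatic carbon.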